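Swapping the Hydroxyphenyl of Compound 3 for a Pyrrole

The compounds below may be only part of what the source reports. "The series", "measured", "known", "first", "only" and "open" are said of these compounds alone.

Measured so far in a functional assay on JAR cells (Homo sapiens) for inhibition, read by MTT assay, with a stated time of 72 h, tested at 10 uM; a higher number here means more inhibition at the concentration tested (going by the name of the read-out), a lower number less inhibition:
compound 1, `CCOC(=O)C1=C(Nc2ccccc2)S/C(=C\c2ccc(Br)c(O)c2)C1=O`, gives 39.8%
compound 2, `CCOC(=O)C1=C(Nc2ccccc2)S/C(=C\c2cccc(C(=O)O)c2)C1=O`, gives 50.6%
compound 3, `CCOC(=O)C1=C(Nc2ccccc2)S/C(=C\c2ccccc2O)C1=O`, gives 89.4%

Compound 3 stands highest of the three numbers. The steps of a number 49.6 percentage points higher from compound 1 to compound 3 (beyond the scatter) and a number 38.8 percentage points higher from compound 2 to compound 3 (beyond the scatter) both lie beyond the scatter, and the step of a number 10.8 percentage points higher from compound 1 to compound 2 (beyond the scatter) is modest by comparison. Compound 4, `CCOC(=O)C1=C(Nc2ccccc2)S/C(=C\c2cc[nH]c2)C1=O`, differs from compound 3 by 1H-pyrrol-3-yl in place of 2-hydroxyphenyl on a double-bonded chain carbon bound to a double-bonded ring carbon. The two measured steps that arrive at compound 3 bear on this change: each shows that exchanging the 2-hydroxyphenyl for another aromatic group in this place lowers inhibition considerably. Going by the values given here, no measured compound carries a pyrrole, so the size is uncertain, but a large drop is expected, a number 44.4 percentage points lower from compound 3 to compound 4 (beyond the scatter). Compound 4 is therefore estimated at 45% in this assay, with a range from 20% to 75%.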

Compound 4, a percentage reported as inhibition, at one concentration (the size of the read-out at that concentration, not a potency): 19.5%
For compound 4 the middle estimate is 25.5 percentage points above the measured one, outside the stated range (below it).
By their numbers in this assay, from the lowest: compound 4; then compound 1; then compound 2; then compound 3.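

In this assay, the 1H-pyrrol-3-yl group, a five-membered aromatic ring on the double-bonded chain carbon, falls below all three phenyl-bearing compounds (a number 69.9 percentage points lower from compound 3 to compound 4 (beyond the scatter); a number 31.1 percentage points lower from compound 2 to compound 4 (beyond the scatter); a number 20.3 percentage points lower from compound 1 to compound 4 (beyond the scatter)). This place therefore spans a wider range than the substituted phenyl groups alone had shown, and the smallest of these three steps is still a modest one. Nothing available here explains the loss.

From the compounds shown here alone, whether an unsubstituted phenyl or a 2-aminophenyl would keep the inhibition of compound 3 remains open. So does whether a 1H-pyrrol-2-yl would behave like the 1H-pyrrol-3-yl of compound 4.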